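The source may hold more compounds than are shown below. What is called first, only, known or untested is meant among the compounds shown, and "the series" means these compounds.

Working notes on the series. Among the compounds with values here, the shared core of compound 1 `CCCCNc1nc(N)nc(C)c1CC` carries a short chain; in an assay on HEK293 cells for agonist activity at Toll-like receptor 8 (Homo sapiens), read by spectrophotometry (on this read-out lower numbers stand for an effect already at smaller amounts and higher numbers for an effect only at larger amounts of compound), compound 1 gives 1660 nM, the highest of the two numbers so far. Within the data shown here, compound 2 `CCCCNc1nc(N)nc(C)c1CCCN1Cc2ccccc2C1`, with a longer substituent at the same place, gives 29 nM in this assay, and the gap between compound 1 and compound 2 lies beyond the scatter; only this one pair speaks for the effect of a longer chain here. Compound 3 `CCCCNc1nc(N)nc(C)c1CCC(C)(C)O` is the next compound to be measured: relative to compound 1 the change is 1-hydroxy-1-methylethyl in place of hydrogen on a saturated chain carbon, two bonds along the chain from an aromatic carbon. Among the measured compounds shown here, no measured pair covers this change, and the extension in compound 3 is different in kind from that of compound 2. The expected step is a 3.3-fold lower number from compound 1 to compound 3 (0.52 log units; beyond the scatter), a moderate move toward a lower number. For compound 3 the estimate in this assay is 500 nM, with a range from 150 nM to 2000 nM.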

Compound 3, half-maximal effective concentration: 3140 nM
Beside the measured number, compound 3's estimate is 6.3-fold (0.80 log units) below it; measured number outside the range, above it.
By their numbers in this assay, from the lowest: compound 2; then compounds 1 and 3 (each within the scatter of the next).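

In this assay, 1-hydroxy-1-methylethyl in place of hydrogen on a saturated chain carbon, two bonds along the chain from an aromatic carbon, gives a 1.9-fold higher number from compound 1 to compound 3 (0.28 log units; within the scatter), so this position takes the group without a readable change. Going from ethyl to 3-hydroxy-3-methylbutyl therefore shows that a longer substituent at this place does not by itself bring a low number, and the only low number so far remains that of compound 2 at 29 nM in this assay. The data at hand offer nothing that explains this outcome.

The compounds shown leave open whether a plain alkyl chain of similar length would behave like the 3-hydroxy-3-methylbutyl chain. They also leave open what a simple amine or a carboxylic acid at this place would give.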